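This account rests on a few compounds, and the source may have more. Where it says the series, first, only, none or still open, it means among the compounds named here.

In an ADME assay on WI-38 cells (Homo sapiens) for cytotoxicity, read by MTT assay, with a stated time of 72 h (a lower number here means a stronger inhibitor, a higher number a weaker inhibitor), compound 1 (`O=C(CCc1cccc2c1B(O)OC2)Nc1ccc(Cl)cc1`) gives > 100000 nM as a limit. Compound 2 (`CCOC(=O)c1ccc(NC(=O)CCc2cccc3c2B(O)OC3)cc1`) gives > 100000 nM as a limit. Compound 3 (`C#Cc1cccc(NC(=O)CCc2cccc3c2B(O)OC3)c1`) gives > 100000 nM as a limit, not a number. Within the data shown here, the series so far stands at the limit of > 100000 nM in this assay, at which 3 of the 3 values shown sit, as its only reading. From compound 3 to compound 4 (`O=C(CCc1cccc2c1B(O)OC2)Nc1cccc(-c2cccc(Cl)c2)c1`) the change (3-chlorophenyl in place of ethynyl on an aromatic carbon) is 3-chlorophenyl in place of ethynyl on an aromatic carbon. Among the measured compounds shown here, the one measured step (a step that the two limits leave unreadable from compound 1 to compound 2) puts ethoxycarbonyl in place of chloro on an aromatic carbon and has no readable size, so no size carries over. No step beyond the scatter is expected in this assay, and the expected step is a number no higher from compound 3 to compound 4 (the limit leaves the size open) on this estimate. The estimate for compound 4 is 100000 nM (expected range 40000 nM to 250000 nM).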

Compound 4, half-maximal inhibitory concentration: 58000 nM
Beside the measured number, compound 4's estimate is 1.7-fold (0.24 log units) above it; the measured number falls inside the stated range.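

In this assay, among these compounds, 3-chlorophenyl in place of ethynyl on an aromatic carbon gives an at least 1.7-fold lower number from compound 3 to compound 4 (0.23 log units; that floor lies within the scatter) and yields the first reading that is a number rather than a limit. Only a floor is available, so the true size of this change stays unread. Compound 4 alone stands off the shared limit: the limit of > 100000 nM in this assay, at which 3 of the 4 values shown sit.

Going by these compounds, whether the chlorine matters remains open, as a plain phenyl at this position would test. An aminophenyl or a carboxylic acid there could show whether the reading depends on the nature of the added ring.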